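The compounds below may be only part of what the source reports. "The series", "measured", "known", "first", "only" and "open" are said of these compounds alone.

Among the measured compounds shown here, compound 2 `Cc1cc(/C=C/C#N)cc(C)c1Oc1cc(Nc2ccc(C#N)cc2)c(N)cc1C(=O)NCCC(F)F` sits at the bottom of the two numbers measured so far. In an ADME assay on liver (Homo sapiens) for metabolic stability, read by LC-MS, using S9 fraction and NADPH, with a stated time of 45 min, tested at 1 uM (on this read-out higher numbers stand for a longer-lived compound and lower numbers for a shorter-lived compound), compound 2 gives 0.233 h, the lowest of the pair; its nearest neighbour, compound 1 `CCNC(=O)c1cc(N)c(Nc2ccc(C#N)cc2)cc1Oc1c(C)cc(/C=C/C#N)cc1C`, gives in this assay 1.02 h. Compound 3 `CNC(=O)c1cc(N)c(Nc2ccc(C#N)cc2)cc1Oc1c(C)cc(/C=C/C#N)cc1C` has not yet been measured. It differs from compound 2 by hydrogen in place of 2,2-difluoroethyl on a saturated chain carbon bound to an amide-type nitrogen, so that the chain on the amide nitrogen is cut back to methyl. For the measured compounds named here, one measured step bears on this change: a 4.4-fold lower number from compound 1 to compound 2 (0.64 log units; beyond the scatter), where adding difluoromethyl to that chain shortened the half-life. The move to compound 3 goes the other way and further, taking the fluorinated part of the chain off altogether. Because of a 4.4-fold lower number from compound 1 to compound 2 (0.64 log units; beyond the scatter) a longer half-life is expected for compound 3, a step of about a 4.3-fold higher number from compound 2 to compound 3 (0.63 log units; beyond the scatter), bringing it close to compound 1. The estimate for compound 3 is 1 h, with a range from 0.4 h to 2.5 h.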

Compound 3, half-life: 1.6 h
The estimate for compound 3 lay 1.6-fold (0.20 log units) below the measured number; low and high end bracket the measured number.
By their numbers in this assay, from the lowest: compound 2; then compounds 1 and 3 (each within the scatter of the next).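

In this assay, cutting the chain back gives a 6.9-fold higher number from compound 2 to compound 3 (0.84 log units; beyond the scatter) and restores a half-life in the range of compound 1, so the short half-life of compound 2 goes with its (3,3-difluoropropyl)carbamoyl group and not with the shared core. The step between the two short chains, a 1.6-fold higher number from compound 1 to compound 3 (0.20 log units; within the scatter), shows that methyl and ethyl on the amide nitrogen cannot be told apart on this read-out. Among these three compounds, only the difluorinated chain stands out, and nothing measured here explains why.

The compounds shown leave open whether the fluorine atoms or the extra chain length matter more, a question that a plain propyl chain on the amide nitrogen would address. As far as these compounds go, how a hydroxyethyl chain or a cyclopropyl group would behave at this position also remains open.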